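This account rests on a few compounds, and the source may have more. Where it says the series, first, only, none or still open, it means among the compounds named here.

Working notes on the series. All three measured compounds share one core. In an assay on mitochondria from L6 cells (Rattus norvegicus) for activation, with a stated time of 90 min (a lower number here means that less compound is needed, a higher number that more compound is needed for the effect), compound 1 `Fc1ccccc1Nc1nc2nonc2nc1NC1CCCCC1` gives 13400 nM. Compound 2 `Fc1ccc(Nc2nc3nonc3nc2Nc2ccccc2F)cc1` gives 2300 nM in this assay, and compound 3 `COc1cccc(Nc2nc3nonc3nc2Nc2ccccc2F)c1` gives 830 nM. Compound 3 therefore holds the lowest number of the three: the nearest is compound 2, separated by a 2.8-fold lower number from compound 2 to compound 3 (0.44 log units; beyond the scatter), and the furthest is compound 1, separated by a 16-fold lower number from compound 1 to compound 3 (1.21 log units; beyond the scatter). The remaining pair is covered by a 5.8-fold lower number from compound 1 to compound 2 (0.77 log units; beyond the scatter).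

Within the data shown here, compound 4 `COc1ccc(Nc2nc3nonc3nc2Nc2ccccc2F)cc1` is the next compound to be measured. 4-methoxyphenyl in place of 3-methoxyphenyl on a nitrogen on an aromatic ring No measured step compares 3-methoxyphenyl with 4-methoxyphenyl directly; the steps that bear on the change, a 2.8-fold lower number from compound 2 to compound 3 (0.44 log units; beyond the scatter) and a 16-fold lower number from compound 1 to compound 3 (1.21 log units; beyond the scatter), exchange the whole group on the nitrogen, and both are larger than a rearrangement of the same atoms within the ring is expected to produce. The step in this assay is thus expected to be small, a 1.6-fold higher number from compound 3 to compound 4 (0.19 log units; within the scatter), leaning toward a somewhat higher number but not clearly beyond the scatter. Compound 4 is estimated at 1300 nM, with a range from 400 nM to 4000 nM.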

Compound 4, half-maximal effective concentration: 1600 nM
For compound 4 the middle estimate is 1.2-fold (0.09 log units) below the measured one, and the stated range covers the measured number.
By their numbers in this assay, from the lowest: compounds 3, 4 and 2 (each within the scatter of the next, the first and the last beyond it); then compound 1.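

In this assay, among these compounds, the first direct comparison of the two methoxyphenyl groups on this nitrogen gives a 1.9-fold higher number from compound 3 to compound 4 (0.29 log units; within the scatter), so moving the methoxy within the ring, from 3-methoxyphenyl to 4-methoxyphenyl, stays within the scatter. Methoxy in place of fluoro on the same ring also stays within the scatter, at a 1.4-fold lower number from compound 2 to compound 4 (0.16 log units; within the scatter), even though compound 2 and compound 3 are separated by a 2.8-fold lower number from compound 2 to compound 3 (0.44 log units; beyond the scatter). Exchanging cyclohexyl for 4-methoxyphenyl gives an 8.4-fold lower number from compound 1 to compound 4 (0.92 log units; beyond the scatter), so all three compounds with an aromatic group at this place give lower numbers than compound 1.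

The data in hand offer no explanation for the sizes of these steps. On these data alone, whether an amine or a carboxylic acid on this ring, or a longer chain in place of methoxy, would give a step beyond the scatter remains open.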